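A few compounds are considered here, and "the series" means these few. Any claim that something is new, unique, unknown or untested is made for them only; others in the source may bear on it.

Compound 1 `O=C1COc2ccc(-c3cccc(NS(=O)(=O)c4ccc(F)cc4)c3)cc2N1C1CC1` gives > 40000 nM in a functional assay on A-375 cells (Homo sapiens) for antiproliferative activity, read by MTT assay, with a stated time of 72 h; a lower number here means a stronger inhibitor, a higher number a weaker inhibitor.
Compound 2 `Cc1ccc(N2C(=O)COc3ccc(-c4cnc5ccccc5c4)cc32)cc1` gives > 40000 nM in this assay.
Compound 3 `O=C1COc2ccc(-c3cnc(Cl)c(NS(=O)(=O)c4ccc(F)cc4)c3)cc2N1c1ccc(Cl)cc1` gives 30600 nM in this assay.

The value for compound 2 is only a limit of the assay, not a number. Compound 1 sits at the same limit, (the limit of > 40000 nM in this assay, at which 2 of the 3 values shown sit), so compound 2 cannot be placed against it. Compound 3 gives a measured number, 30600 nM, and compound 2 cannot be ranked against it either. Compound 4 `O=C1COc2ccc(-c3cnc4ccccc4c3)cc2N1C1CCCCC1` differs from compound 2 in one place: cyclohexyl in place of 4-methylphenyl on an amide-type nitrogen in a ring. For the measured compounds named here, no measured pair shows this change, so the expectation rests on the weak showing of the shared core. In this assay the step of a number no higher from compound 2 to compound 4 (the limit leaves the size open) is expected to be none beyond the scatter. Compound 4 is estimated at 40000 nM, within 20000 nM to 80000 nM, most likely again reported only as a limit.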

Compound 4, half-maximal inhibitory concentration: > 40000 nM
Compound 4: only a limit was reported (the forecaster's own chance of this, stated with the estimate: 75%); the middle value sits exactly at the limit.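

Compound 2 and compound 4 both give only a limit in this assay, not a number, so no step can be read between them: the limit of > 40000 nM in this assay, at which 3 of the 4 values shown sit.

As far as these compounds go, whether cyclohexyl and 4-methylphenyl differ at all in their effect on the shared core remains open.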